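Ether for amine on the shared core: compound 3

The source may hold more compounds than are shown below. What is called first, only, known or untested is meant among the compounds shown, and "the series" means these compounds.

Measured so far:
compound 1 `COCC(COC)N(C)c1nc(C)nc2c1nnn2-c1ccc(C(C)C)cc1Br` — 21.3 nM
compound 2 `CCCCN(CC)c1nc(C)nc2c1ncn2-c1ccc(C(C)C)cc1Br` — 4.3 nM

Two compounds have been run in an in vitro assay on 293-EBNA cells for binding affinity to corticotropin-releasing factor receptor 1 (Homo sapiens); a higher number here means a weaker inhibitor, a lower number a stronger inhibitor. Compound 1 gives 21.3 nM, the highest of the two numbers; compound 2 gives 4.3 nM, and the gap between them lies beyond the scatter. Going by the values given here, the two differ in more than one place, so no single step between them is computed.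

Compound 3 `COCC(COC)Oc1nc(C)nc2c1nnn2-c1ccc(C(C)C)cc1Br` is not yet measured. It differs from compound 1 in one place: a group of 8 heavy atoms (5 carbon, 3 oxygen; no ring) in place of a group of 9 heavy atoms (6 carbon, 1 nitrogen, 2 oxygen; no ring), on an aromatic carbon, the place being next to the ring nitrogen and ortho to a fused ring. Among the compounds with values here, no measured step of this kind exists, so the expectation rests on the general size of such swaps; a modest weakening beyond the scatter is expected, a 1.9-fold higher number from compound 1 to compound 3 (0.27 log units; within the scatter). Compound 3 is therefore estimated at 40 nM, with a range from 10 nM to 160 nM.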

Compound 3, inhibition constant: 7.1 nM
For compound 3 the middle estimate is 5.6-fold (0.75 log units) above the measured one; measured number below the stated range.
By their numbers in this assay, from the lowest: compounds 2 and 3 (each within the scatter of the next); then compound 1.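

In this assay, going by these compounds alone, replacing the amine link with an ether oxygen on the aromatic carbon next to the ring nitrogen gives a 3.0-fold lower number from compound 1 to compound 3 (0.48 log units; beyond the scatter), the first single-place step. This position therefore responds to the atom joining the side chain to the shared core, even though the two groups have the same counts of hydrogen-bond donors and acceptors and differ by a single heavy atom. No available evidence explains this gain, so the step stands as an observation only.

A single pair cannot show whether the ether oxygen or the loss of the methyl group on the amine nitrogen accounts for the step. It also leaves open how a sulfur link or a longer chain would behave here, and whether the ether gives a similar step with the side chain of compound 2.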